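Benzyl for Dichlorophenyl: Cytotoxicity in a Small Series

A few compounds are considered here, and "the series" means these few. Any claim that something is new, unique, unknown or untested is made for them only; others in the source may bear on it.

compound 1 `CC(Sc1nnc(-c2ccncc2)s1)C(=O)Nc1ccc(Cl)cc1Cl`: > 50000 nM
compound 2 `CC(Sc1nnc(-c2ccncc2)s1)C(=O)NCc1ccccc1Cl`: > 50000 nM
compound 3 `O=C(CCSc1nnc(-c2ccncc2)s1)Nc1ccc(Cl)cc1Cl`: > 50000 nM

Of the compounds shown here, three have been tested in an ADME assay on HepG2 cells (Homo sapiens) for cytotoxicity, with a stated time of 3 days; on this read-out lower numbers stand for higher toxicity in this test and higher numbers for lower toxicity in this test. For compound 1 the readout is > 50000 nM, which is a limit of the assay and not a number. For compound 2 the readout is > 50000 nM, again a limit of the assay rather than a measured value. For compound 3 the readout is > 50000 nM, also a limit of the assay.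

Compound 1 and compound 2 differ in one place: 2-chlorobenzyl in place of 2,4-dichlorophenyl on an amide-type nitrogen. The step between them, a step that the two limits leave unreadable from compound 1 to compound 2, cannot be read because of the limit of > 50000 nM in this assay, at which 3 of the 3 values shown sit.

Compound 3 shares its atoms with compound 1 but joins them differently; the difference between the two cores is not broken down here.

Compound 4 `O=C(CCSc1nnc(-c2ccncc2)s1)NCc1ccccc1Cl` is not yet measured. It stands to compound 3 as compound 2 stands to compound 1: 2-chlorobenzyl in place of 2,4-dichlorophenyl on an amide-type nitrogen. This is the same change, made on the same kind of amide-type nitrogen.

The step from compound 3 to compound 4 is expected to be a step that the limit leaves unreadable from compound 3 to compound 4, and this expectation rests on compound 1 and compound 2 giving a step that the two limits leave unreadable from compound 1 to compound 2, since (the limit of > 50000 nM in this assay, at which 3 of the 3 values shown sit). Compound 4 is therefore estimated to give 100000 nM in this assay, most likely reported again as a limit.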

Compound 4, half-maximal cytotoxic concentration: > 50000 nM
Compound 4 gave a limit, no number (the forecaster's own chance of this, stated with the estimate: 85%); the middle value does not contradict the limit.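

Compound 3 and compound 4 both give a limit and not a number in this assay, so no step can be read between them, because the values stop at the same point: the limit of > 50000 nM in this assay, at which 4 of the 4 values shown sit.

The compounds shown leave open how far any of the four lies past that limit, and whether 2-chlorobenzyl in place of 2,4-dichlorophenyl on an amide-type nitrogen shifts the read-out at all.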